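The compounds below may be only part of what the source reports. "The series", "measured", "known", "first", "only" and "open" are said of these compounds alone.

Of the compounds shown here, three built on one shared core have been measured in a functional assay on HT-29 cells (Homo sapiens) for cytotoxicity, read by sulforhodamine B assay; a lower number here means a stronger inhibitor, a higher number a weaker inhibitor. Compound 1 `C=C1[C@@H](OC(C)=O)C[C@@H]2[C@](C)(COC=O)[C@H](OC(C)=O)CC[C@@]2(C)[C@@H]1C[C@@H](Nc1ccc(Br)cc1)C1=CCOC1=O` gives 13200 nM in this assay. Compound 2 `C=C1[C@@H](OC(C)=O)C[C@@H]2[C@](C)(COC=O)[C@H](OC(C)=O)CC[C@@]2(C)[C@@H]1C[C@@H](Nc1cccc2ccccc12)C1=CCOC1=O` gives 8670 nM in this assay, and the step of a 1.5-fold lower number from compound 1 to compound 2 (0.18 log units; within the scatter) stays within the scatter. Compound 3 `C=C1[C@@H](OC(C)=O)C[C@@H]2[C@](C)(COC=O)[C@H](OC(C)=O)CC[C@@]2(C)[C@@H]1C[C@@H](Nc1ccc(C(=O)O)cc1)C1=CCOC1=O` gives 37200 nM in this assay, the highest number of the three, since the step of a 2.8-fold higher number from compound 1 to compound 3 (0.45 log units; beyond the scatter) and the step of a 4.3-fold higher number from compound 2 to compound 3 (0.63 log units; beyond the scatter) both move toward a weaker inhibitor.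

Compound 4 `C=C1[C@@H](OC(C)=O)C[C@@H]2[C@](C)(COC=O)[C@H](OC(C)=O)CC[C@@]2(C)[C@@H]1C[C@@H](Nc1ccccc1F)C1=CCOC1=O` has not been measured. It differs from compound 3 in one place: 2-fluorophenyl in place of 4-carboxyphenyl on an amine nitrogen. Going by the values given here, the steps that bear on this change are a 2.8-fold higher number from compound 1 to compound 3 (0.45 log units; beyond the scatter) and a 4.3-fold higher number from compound 2 to compound 3 (0.63 log units; beyond the scatter), both modest and beyond the scatter. Taking the carboxy group away in compound 4 is therefore expected to lower the number by a comparable modest step, a 3.1-fold lower number from compound 3 to compound 4 (0.49 log units; beyond the scatter). Among the compounds with values here, no measured compound carries fluorine on that ring, so the expectation leans on compound 1 with 13200 nM. Compound 4 is expected to give about 12000 nM in this assay, within a range from 5000 nM to 30000 nM.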

Compound 4, half-maximal inhibitory concentration: 9760 nM
For compound 4 the middle estimate is 1.2-fold (0.09 log units) above the measured one, within the range that was stated.
By their numbers in this assay, from the lowest: compounds 2, 4 and 1 (each within the scatter of the next); then compound 3.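

In this assay, going by these compounds alone, a third group now sets the 4-carboxyphenyl compound apart: 2-fluorophenyl in its place on the amine nitrogen brings a 3.8-fold lower number from compound 3 to compound 4 (0.58 log units; beyond the scatter) and, like the earlier steps to that compound, this one lies beyond the scatter. The other two new steps (a 1.1-fold higher number from compound 2 to compound 4 (0.05 log units; within the scatter) and a 1.4-fold lower number from compound 1 to compound 4 (0.13 log units; within the scatter)) stay within the scatter, so 2-fluorophenyl, 4-bromophenyl and naphthalen-1-yl cannot be told apart at this position, even though they carry fluorine, bromine or no halogen at all. Nothing available here explains why the carboxy compound stands apart.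

A methyl ester or a primary amide in place of the carboxylic acid would show whether the acid itself goes with the higher number. Every compound shown carries an aromatic ring on this nitrogen, so what a plain alkyl chain or a cyclohexyl group would do there remains open.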